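Swapping 1H-indol-5-yl for 1H-indol-6-yl

A few compounds are considered here, and "the series" means these few. Any claim that something is new, unique, unknown or untested is made for them only; others in the source may bear on it.

In a functional assay on HeLa cells (Homo sapiens) for cytotoxicity, read by MTT assay, with a stated time of 48 h (a higher number here means a weaker inhibitor, a lower number a stronger inhibitor), compound 1 `COc1cc(N/C=C\C(=O)c2c(-c3ccc(Cl)cc3)nc3ccccn23)cc(OC)c1` gives 14600 nM with 3,5-dimethoxyphenyl on an amine nitrogen. Compound 2 `O=C(/C=C\Nc1ccc2[nH]ccc2c1)c1c(-c2ccc(Cl)cc2)nc2ccccn12` gives 3240 nM with 1H-indol-5-yl in that place, the lower of the two numbers and therefore the stronger result so far. Among the compounds with values here, the only measured step (a 4.5-fold lower number from compound 1 to compound 2 (0.65 log units; beyond the scatter)) is modest but lies beyond the scatter, and it is the one piece of evidence that bears on the next compound.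

Compound 3 `O=C(/C=C\Nc1ccc2cc[nH]c2c1)c1c(-c2ccc(Cl)cc2)nc2ccccn12` carries 1H-indol-6-yl in place of 1H-indol-5-yl on an amine nitrogen, so it has the same atoms as compound 2, joined differently. The measured step exchanged two quite different groups, whereas this change keeps the same kind of group. Within the data shown here, no measured pair compares two such isomers, so the data offer no firm direction. No step beyond the scatter is expected in this assay and the estimated change (a 1.1-fold higher number from compound 2 to compound 3 (0.03 log units; within the scatter)) is correspondingly small. Compound 3 is estimated at 3500 nM with an expected range from 1300 nM to 9000 nM when measured.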

Compound 3, half-maximal inhibitory concentration: 10900 nM
For compound 3 the middle estimate is 3.1-fold (0.49 log units) below the measured one; measured number above the stated range.
By their numbers in this assay, from the lowest: compound 2; then compounds 3 and 1 (each within the scatter of the next).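

In this assay, moving the attachment point from 1H-indol-5-yl to 1H-indol-6-yl leaves the atoms unchanged yet gives a 3.4-fold higher number from compound 2 to compound 3 (0.53 log units; beyond the scatter), so the response at this place on the amine nitrogen depends on how the group is joined and not only on what it contains. The earlier advantage over 3,5-dimethoxyphenyl therefore does not belong to indole groups in general: the comparison shows a 1.3-fold lower number from compound 1 to compound 3 (0.13 log units; within the scatter), which leaves the 1H-indol-6-yl and 3,5-dimethoxyphenyl groups unseparated, and only the 1H-indol-5-yl group in compound 2 stands apart from both. No available evidence explains why the two isomers differ.

The compounds shown leave open whether the result follows a trend across attachment points, which 1H-indol-4-yl or 1H-indol-7-yl would help to test. They also leave open whether the hydrogen on the indole nitrogen matters, a question that 1-methyl-1H-indol-5-yl, with a methyl group in place of that hydrogen, could address.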